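The compounds below may be only part of what the source reports. "The series", "measured", "known", "first", "only" and "open" are said of these compounds alone.

Compound 1 `O=C(c1oc(C(F)(F)F)nc1-c1ccccc1F)N1CCN(c2cccc(Cl)c2)CC1`: "not active" (no number reported)
Compound 2 `Cc1nc(-c2ccccc2)c(C(=O)N2CCN(c3cccc(C)c3C)CC2)o1`: 35 nM

Both compounds were tested in a functional assay on HL-60 cells (Homo sapiens) for inhibition, read by MTT assay, with a stated time of 72 h; on this read-out lower numbers stand for stronger inhibition and higher numbers for weaker inhibition. For the measured compounds named here, compound 2 carries the only number, 35 nM, whereas compound 1 was reported as "not active" (no number reported), so no measured step is available as a guide. Compound 3 `C=C(C)c1ccc(N2CCN(C(=O)c3oc(C)nc3-c3ccccc3)CC2)cc1` has yet to be measured. It keeps the rest of compound 2 and changes one group: 4-(1-methylethenyl)phenyl in place of 2,3-dimethylphenyl on an amine nitrogen in a ring. In words, 4-(1-methylethenyl)phenyl stands in place of 2,3-dimethylphenyl on an amine nitrogen in a ring. The data do not show how this exchange acts in this assay, so any forecast is loose. With compound 2 at 35 nM as the only anchor, a moderate move towards weaker inhibition is expected, and the expected size is a 2.3-fold higher number from compound 2 to compound 3 (0.36 log units; beyond the scatter). For compound 3 the estimated value is 80 nM, with an expected range from 15 nM to 450 nM.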

Compound 3, half-maximal inhibitory concentration: "not active" (no number reported)
No number was reported for compound 3; the estimate stays without a comparison.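

For the compounds shown here, compound 3 carries no number, just as compound 1 does, so no step from compound 2 to compound 3 can be read, and no evidence bears on this result. In this assay the compounds shown leave open how the group on the amine nitrogen in a ring affects inhibition.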